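This account rests on a few compounds, and the source may have more. Where it says the series, first, only, none or still open, it means among the compounds named here.

Compound 1 `CCc1ccccc1OC(C)C1=NCCN1` gives 100 nM in a functional assay on CHO cells for agonist activity at Alpha-2C adrenergic receptor (Homo sapiens) (on this read-out higher numbers stand for an effect only at larger amounts of compound and lower numbers for an effect already at smaller amounts), the lowest of the two numbers measured. Among the compounds with values here, compound 2 `COc1ccccc1OC(C)C1=NCCN1` gives 9770 nM in this assay, and the only measured step, a 98-fold higher number from compound 1 to compound 2 (1.99 log units; beyond the scatter), shows a large loss on replacing ethyl with methoxy at that position. Compound 3 `CC(=O)c1ccccc1OC(C)C1=NCCN1` differs from compound 1 by acetyl in place of ethyl on an aromatic carbon. Because the step of a 98-fold higher number from compound 1 to compound 2 (1.99 log units; beyond the scatter) shows how sharply this position responds to a different group, a further loss is expected for compound 3, though acetyl is not methoxy and the size is uncertain. Compound 3 is estimated to reach 1500 nM (range 200 nM to 12000 nM), an expected step of a 15-fold higher number from compound 1 to compound 3 (1.18 log units; beyond the scatter).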

Compound 3, half-maximal effective concentration: 200 nM
Compound 3: the middle estimate sits 7.5-fold (0.88 log units) above what was measured, within the range that was stated.
By their numbers in this assay, from the lowest: compounds 1 and 3 (each within the scatter of the next); then compound 2.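

In this assay this position does not turn against every replacement of ethyl: acetyl and ethyl cannot be told apart here (a 2.0-fold higher number from compound 1 to compound 3 (0.30 log units; within the scatter)). Methoxy alone stands apart among the three groups (a 49-fold lower number from compound 2 to compound 3 (1.69 log units; beyond the scatter)), so the sharp response seen earlier does not extend to acetyl. Nothing available explains why acetyl and methoxy differ so widely at this position. On these data alone, it remains open whether an amine, a carboxylic acid or a longer alkyl chain on this aromatic carbon would stay with ethyl and acetyl or fall with methoxy.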